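Working notes: cytotoxicity of compounds 1 to 3

The compounds below may be only part of what the source reports. "The series", "measured", "known", "first", "only" and "open" are said of these compounds alone.

Measured so far:
- compound 1, `O=C(Nc1cc(-c2nc3ccccc3o2)ccc1F)c1cc([N+](=O)[O-])ccc1Cl`, in an ADME assay on HepG2 cells (Homo sapiens) for cytotoxicity, with a stated time of 72 h; a higher number here means that more compound is needed for the effect, a lower number that less compound is needed: > 25000 nM, a limit of the assay
- compound 2, `O=C(Nc1cccc(-c2nc3ccccc3s2)c1)c1cc([N+](=O)[O-])ccc1Cl`, in this assay: > 27000 nM, a limit of the assay

Compound 2 stands only at a limit in this assay; no number is reported for it. Among the measured compounds shown here, the one other value shown, for compound 1, is likewise a limit, so the two measured compounds give no spread at all in this assay: both sit at the top of the measured range (the limit of > 25000 nM in this assay, at which 1 of the 2 values shown sits, (the limit of > 27000 nM in this assay, at which 1 of the 2 values shown sits)). For the measured compounds named here, no step between measured compounds is available.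

Compound 3, `O=C(Nc1cc(-c2nc3ccccc3s2)ccc1F)c1cc([N+](=O)[O-])ccc1Cl`, is to be measured in this assay. It differs from compound 2 by fluoro in place of hydrogen on an aromatic carbon. Given that both measured compounds sit at the limit in this assay, no step beyond the usual scatter is expected from compound 2 to compound 3; the most likely outcome is that compound 3 is again reported as a limit. The estimated step is a step that the limit leaves unreadable from compound 2 to compound 3. For compound 3 the expected value in this assay is 30000 nM, with a range from 12000 nM to 80000 nM.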

Compound 3, half-maximal effective concentration: > 25000 nM
Compound 3 was reported as a limit; the forecaster's own chance of this, stated with the estimate: 80%; the middle value is on the limit's open side.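

No new step can be read in this assay: compound 1, compound 2 and compound 3 are all reported as limits, so the comparisons of compound 3 with compound 2 and compound 1 have no readable size. The compounds shown leave open whether either change alters cytotoxicity, and at what concentration any of the three reaches the half-maximal effect.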